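Methoxy for methyl on the benzylamine of a cytotoxicity series

This account rests on a few compounds, and the source may have more. Where it says the series, first, only, none or still open, it means among the compounds named here.

Measured so far:
compound 1, `COc1cc(/C=C/c2nc(NCc3ccccc3)c3sccc3n2)cc(OC)c1OC`: > 50000 nM
compound 2, `COc1cc(/C=C/c2nc(NCc3ccc(C)cc3)c3sccc3n2)cc(OC)c1OC`: > 50000 nM

Compound 1 carries an unsubstituted benzyl group on the shared core. In an ADME assay on RAW264.7 cells (Mus musculus) for cytotoxicity, read by MTT assay (a lower number here means a stronger inhibitor, a higher number a weaker inhibitor), compound 1 gives only a limit, > 50000 nM. Compound 2 carries a methyl on an aromatic carbon of that benzyl group. In this assay compound 2 likewise gives only a limit, > 50000 nM. Within the data shown here, the one step between them, a step that the two limits leave unreadable from compound 1 to compound 2, therefore cannot be read, and the whole picture rests on (the limit of > 50000 nM in this assay, at which 2 of the 2 values shown sit).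

Compound 3, `COc1ccc(CNc2nc(/C=C/c3cc(OC)c(OC)c(OC)c3)nc3ccsc23)cc1`, differs from compound 2 in one place: methoxy in place of methyl on an aromatic carbon. Among the measured compounds shown here, no measured step carries a readable size, so the only guide is that both neighbours sit at the limit. Compound 3 is expected to stay there as well, with no step beyond the scatter: its estimated step is a step that the limit leaves unreadable from compound 2 to compound 3. For compound 3 the expected value in this assay is 70000 nM, within a range from 30000 nM to 250000 nM, most likely again reported only as a limit.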

Compound 3, half-maximal inhibitory concentration: > 50000 nM
Compound 3: only a limit was reported; the forecaster's own chance of this, stated with the estimate: 85%; the middle value is on the limit's open side.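

Compound 3 gives only a limit in this assay, so neither the step from compound 2 to compound 3 nor the step from compound 1 to compound 3 can be read: the limit of > 50000 nM in this assay, at which 3 of the 3 values shown sit. The compounds shown leave open whether compound 1, compound 2 and compound 3 differ at all in this assay, and how large a step methyl or methoxy on the benzyl group brings, if any.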